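This account rests on a few compounds, and the source may have more. Where it says the series, first, only, none or still open, it means among the compounds named here.

In a functional assay on BGC-823 cells (Homo sapiens) for cytotoxicity, read by CCK-8 assay, with a stated time of 24 h (on this read-out lower numbers stand for stronger inhibition and higher numbers for weaker inhibition), two close relatives of one core have been measured. Compound 1, `C/C(=C\c1cc(-c2ccccc2)co1)C(N)=O`, carries a plain phenyl on the furan. In this assay compound 1 gives > 50000 nM, which is a limit of the assay and not a number. Compound 2, `C/C(=C\c1cc(-c2ccc(C)cc2)co1)C(N)=O`, adds a methyl on an aromatic carbon of that phenyl. In this assay compound 2 gives > 50000 nM, again a limit rather than a number. The step that the two limits leave unreadable from compound 1 to compound 2 therefore has no readable size because both of its values sit on (the limit of > 50000 nM in this assay, at which 2 of the 2 values shown sit). Compound 3, `C/C(=C\c1cc(-c2ccc(F)cc2)co1)C(N)=O`, is not yet measured; it differs from compound 2 by fluoro in place of methyl on an aromatic carbon. The only measured step that bears on this change is the one from compound 1 to compound 2, and it is unreadable, so no size or direction for the new step can be drawn from the numbers shown. Compound 3 is expected to behave like its neighbours and to give 60000 nM, most likely between 20000 nM and 200000 nM. The estimated step that the limit leaves unreadable from compound 2 to compound 3 is expected to be none beyond the scatter.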

Compound 3, half-maximal inhibitory concentration: > 50000 nM
Compound 3: a limit, no number; the forecaster's own chance of this, stated with the estimate: 85%; the middle value is on the limit's open side.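

In this assay compound 3 gives > 50000 nM as a limit of the assay and not a number. Among the compounds shown here, no step among compound 1, compound 2 and compound 3 can be read, because all three values sit at the same point: the limit of > 50000 nM in this assay, at which 3 of the 3 values shown sit. The compounds shown leave open whether any change on the phenyl alters the value, and by how much.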